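Series notes: the step from compound 3 to compound 4

A few compounds are considered here, and "the series" means these few. Any claim that something is new, unique, unknown or untested is made for them only; others in the source may bear on it.

compound 1, `COc1ccc(C(=O)/C=C/c2ccc(N(C)C)cc2)c2c1C=CC(C)(C)O2`: 2750 nM
compound 2, `CCN(CC)c1ccc(/C=C/C(=O)c2ccc(OC)c3c2OC(C)(C)C=C3)cc1`: 610 nM
compound 3, `COc1ccc(/C=C/C(=O)c2ccc(OC)c3c2OC(C)(C)C=C3)cn1`: > 10000 nM

In a functional assay on SK-OV-3 cells (Homo sapiens) for antiproliferative activity, read by MTT assay, with a stated time of 24 h (on this read-out higher numbers stand for weaker inhibition and lower numbers for stronger inhibition), compound 1 gives 2750 nM and compound 2 gives 610 nM. Going by the values given here, compound 3 gives only a limit of this assay, > 10000 nM, and so sits at the weak end of the numbers so far, at the limit of > 10000 nM in this assay, at which 1 of the 3 values shown sits. Compound 4 is `COc1ccc(C(=O)/C=C/c2ccc(O)cc2)c2c1C=CC(C)(C)O2`; it differs from compound 3 by 4-hydroxyphenyl in place of 6-methoxypyridin-3-yl on a double-bonded chain carbon bound to a double-bonded chain carbon. Among the compounds with values here, two measured steps bear on this: a 4.5-fold lower number from compound 1 to compound 2 (0.65 log units; beyond the scatter) and an at least 3.6-fold higher number from compound 1 to compound 3 (0.56 log units; beyond the scatter). The second shows that 4-(dimethylamino)phenyl at this place is clearly preferable to 6-methoxypyridin-3-yl; compound 4 restores a six-membered aromatic ring of carbon only, now bearing one hydrogen-bond donor. Within the data shown here, no compound with 4-hydroxyphenyl has been measured, so the size is uncertain. A return toward the numbers of compound 1 is expected, estimated as an at least 2.0-fold lower number from compound 3 to compound 4 (0.30 log units; that floor lies within the scatter). Compound 4 is thus expected to give about 5000 nM, within 1500 nM to 20000 nM.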

Compound 4, half-maximal inhibitory concentration: > 10000 nM
Compound 4 was reported as a limit; the forecaster's own chance of this, stated with the estimate: 35%; middle value at least 2.0-fold (0.30 log units) away from the limit.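

In this assay a six-membered aromatic ring of carbon only does not suffice at this place: hydroxy on that ring gives an at least 3.6-fold higher number from compound 1 to compound 4 (0.56 log units; beyond the scatter) and also an at least 16-fold higher number from compound 2 to compound 4 (1.21 log units; beyond the scatter) and leaves activity with the two dialkylamino compounds alone. Compound 3 and compound 4 are both reported only as limits, so the step between them cannot be read and neither ranks above the other. Open, on these data alone, is whether a primary amine or a methoxy group on the same ring would hold activity. Also open, as far as these compounds go, is whether a dipropylamino group would extend the gain seen with diethylamino.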